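A few compounds are considered here, and "the series" means these few. Any claim that something is new, unique, unknown or untested is made for them only; others in the source may bear on it.

Among the compounds with values here, compound 3 `O=C1N/C(=N/c2csc(-c3ccc(Cl)cc3)c2)S/C1=C\c1ccc(Br)cc1` gives 2500 nM in a functional assay on MCF7 cells (Homo sapiens) for cytotoxicity, read by MTT assay, with a stated time of 72 h (on this read-out higher numbers stand for weaker inhibition and lower numbers for stronger inhibition), the highest of the three numbers measured so far. Compound 1 `COc1ccc(/C=C2\S/C(=N\c3csc(-c4ccc(Cl)cc4)c3)NC2=O)cc1` gives 1000 nM and compound 2 `CN(C)c1ccc(/C=C2\S/C(=N\c3csc(-c4ccc(Cl)cc4)c3)NC2=O)cc1` gives 400 nM; the steps of a 2.5-fold higher number from compound 1 to compound 3 (0.40 log units; beyond the scatter) and a 6.3-fold higher number from compound 2 to compound 3 (0.80 log units; beyond the scatter) were modest, as was a 2.5-fold lower number from compound 1 to compound 2 (0.40 log units; beyond the scatter). Compound 4 `O=C1N/C(=N/c2csc(-c3ccc(Cl)cc3)c2)S/C1=C\c1ccc2ccccc2c1` carries naphthalen-2-yl in place of 4-bromophenyl on a double-bonded chain carbon bound to a double-bonded ring carbon. Within the data shown here, none of the measured steps exchanges the whole aryl group, so the three steps bear only indirectly: each change at this ring moved the numbers modestly, never by a large amount. A modest downward step is therefore expected for compound 4, chiefly because compound 3 stands at 2500 nM with room to move. Compound 4 is expected to give 1500 nM, within 500 nM to 5000 nM, meaning a 1.7-fold lower number from compound 3 to compound 4 (0.22 log units; within the scatter).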

Compound 4, half-maximal inhibitory concentration: 1200 nM
Estimate against measurement, compound 4: 1.3-fold (0.10 log units) above; the measured number falls inside the stated range.
By their numbers in this assay, from the lowest: compound 2; then compounds 1 and 4 (each within the scatter of the next); then compound 3.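

In this assay, within the data shown here, this is the first exchange of the whole aryl group on the double-bonded chain carbon, and two six-membered aromatic rings are accepted there: naphthalen-2-yl in place of 4-bromophenyl gives a 2.1-fold lower number from compound 3 to compound 4 (0.32 log units; beyond the scatter). Set against the other aryl groups, the change gives a 1.2-fold higher number from compound 1 to compound 4 (0.08 log units; within the scatter) and a 3.0-fold higher number from compound 2 to compound 4 (0.48 log units; beyond the scatter), so 4-(dimethylamino)phenyl keeps the lowest number of the four. Nothing available explains these differences.

As far as these compounds go, it remains open how naphthalen-1-yl, a pyridine ring or a phenyl ring bearing a carboxylic acid would read at this position.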